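Swapping Chloro for Isobutyl: An Expected Potency Shift

The source may report more compounds than this note shows. Statements on the series, on what has been measured and on what is new or still open speak of the compounds shown alone.

Compound 1 `COCCOc1cc2oc(=O)n(CCC(=O)O)c2cc1Cl`: 50100 nM
Compound 2 `O=C(O)CCn1c(=O)oc2cc(Cl)c(Cl)cc21`: 2000 nM

Both compounds were tested in an assay on HEK293 cells for inhibition of kynurenine 3-monooxygenase (Homo sapiens), read by LC-MS, with a stated time of 20 h; on this read-out lower numbers stand for stronger inhibition and higher numbers for weaker inhibition. Within the data shown here, compound 2 stands at the lowest number of the two; its only neighbour is compound 1, and the single measured step, a 25-fold lower number from compound 1 to compound 2 (1.40 log units; beyond the scatter), came from putting chloro in place of 2-methoxyethoxy on an aromatic carbon.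

Compound 3 `CC(C)Cc1cc2oc(=O)n(CCC(=O)O)c2cc1Cl` differs from compound 2 in one place: isobutyl in place of chloro on an aromatic carbon. Among the measured compounds shown here, no measured step involves an isobutyl group, so nothing directly shows what it does here. The step of a 25-fold lower number from compound 1 to compound 2 (1.40 log units; beyond the scatter) bears on it only loosely, since it concerns the arrival of chloro, not its removal. With the shared core unchanged and an isobutyl group carrying no donor or acceptor, the expectation is a modest step in this assay, somewhat toward weaker inhibition. Compound 3 is therefore estimated at 3500 nM, with a range from 900 nM to 14000 nM, which corresponds to an expected step of a 1.8-fold higher number from compound 2 to compound 3 (0.24 log units; within the scatter).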

Compound 3, half-maximal inhibitory concentration: 794 nM
For compound 3 the middle estimate is 4.4-fold (0.64 log units) above the measured one, outside the stated range (below it).
By their numbers in this assay, from the lowest: compound 3; then compound 2; then compound 1.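

In this assay this position accepts a group of four carbon atoms in place of a single chlorine without any loss of inhibition, and the number even improves: the change gives a 2.5-fold lower number from compound 2 to compound 3 (0.40 log units; beyond the scatter) and so goes the opposite way from a small penalty. Replacing the 2-methoxyethoxy group gives a much wider gap, a 63-fold lower number from compound 1 to compound 3 (1.80 log units; beyond the scatter), so of the three groups seen here, isobutyl gives the lowest number and 2-methoxyethoxy the highest. Nothing available explains this order.

The compounds shown leave open whether the gain follows the carbon count or the branching of isobutyl, a question that a straight butyl chain or a shorter ethyl group would address. They also leave open how an amine or a carboxylic acid at this position would read.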